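A few compounds are considered here, and "the series" means these few. Any claim that something is new, unique, unknown or untested is made for them only; others in the source may bear on it.

Of the compounds shown here, two have been measured. Compound 1 `O=C(Nc1ccc(-c2cnc3cc(N4CCN(C5CC5)CC4)ccn23)cc1)c1ccc([N+](=O)[O-])o1` gives 1920 nM in a functional assay on AGS cells (Homo sapiens) for antiproliferative activity, read by CCK-8 assay, with a stated time of 72 h; a lower number here means a stronger inhibitor, a higher number a weaker inhibitor. Compound 2 `O=C(Nc1ccc(-c2cnc3cc(N4CCCC4)ccn23)cc1)c1ccc([N+](=O)[O-])o1` differs from it only in the amine attached to the shared core and gives 1240 nM in this assay. The step of a 1.5-fold lower number from compound 1 to compound 2 (0.19 log units; within the scatter) is the only measured one, and it leaves the two compounds indistinguishable within the usual scatter, so compound 2 cannot be called stronger or weaker than compound 1.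

Compound 3 `O=C(Nc1ccc(-c2cnc3cc(Br)ccn23)cc1)c1ccc([N+](=O)[O-])o1` has not yet been measured. Its structure differs from compound 2 in that a bromo takes the place of the pyrrolidin-1-yl (bromo in place of pyrrolidin-1-yl on an aromatic carbon). Among the compounds with values here, no measured step describes this kind of exchange: the one step on hand, from compound 1 to compound 2, swaps one ring-containing amine for another and was within the scatter, so it gives little guidance on removing the amine altogether. The expectation for compound 3 is therefore a number close to that of compound 2, with a wide range in both directions, expressed as the step of a 1.3-fold higher number from compound 2 to compound 3 (0.11 log units; within the scatter). On this basis compound 3 is estimated at 1600 nM, within a range from 400 nM to 6500 nM.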

Compound 3, half-maximal inhibitory concentration: 560 nM
Compound 3: middle estimate off by 2.9-fold (0.46 log units), on the high side, within the range that was stated.
By their numbers in this assay, from the lowest: compound 3; then compounds 2 and 1 (each within the scatter of the next).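

Compared with the two ring-bearing amines, bromo at this aromatic carbon, opposite the ring nitrogen, gives a clearer result in this assay: exchanging pyrrolidin-1-yl for bromo produces a 2.2-fold lower number from compound 2 to compound 3 (0.35 log units; beyond the scatter), and exchanging 4-cyclopropylpiperazin-1-yl for bromo produces a 3.4-fold lower number from compound 1 to compound 3 (0.54 log units; beyond the scatter). Both steps are modest but lie beyond the scatter, unlike the exchange between the two amines, so this position does register a change of group, no amine ring is required there for activity, and compound 3 is the strongest of the three. Nothing available explains why the number falls with this exchange.

The compounds shown leave open whether the lower number comes from bromo itself or simply from the loss of the amine ring, and a chloro group or a plain hydrogen at the same carbon would help separate those two readings. From the compounds shown here alone, it also remains open whether a small open-chain amine such as dimethylamino would fall with the two ring-bearing amines or closer to bromo.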